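Defining one ring stereocentre in a fused-core aryl imine

The source may report more compounds than this note shows. Statements on the series, on what has been measured and on what is new or still open speak of the compounds shown alone.

Measured compounds:
Compound 1, `CC1CCC(/C=N/c2ccccc2F)=C2NC=C(C(=O)O)C(=O)N21`: 14.5 umol/kg
Compound 2, `Cc1cccc(/N=C/C2=C3NC=C(C(=O)O)C(=O)N3C(C)CC2)c1`: 0.8 umol/kg

Among the compounds with values here, compound 2 gives the lower of the two numbers obtained in a functional assay on the whole organism with Rattus norvegicus as the target (on this read-out higher numbers stand for an effect only at larger amounts of compound and lower numbers for an effect already at smaller amounts), and the only measured step, an 18-fold lower number from compound 1 to compound 2 (1.26 log units; beyond the scatter), is the one that leads to it. Compound 3, `Cc1cccc(/N=C/C2=C3NC=C(C(=O)O)C(=O)N3[C@H](C)CC2)c1`, is not yet measured. It differs from compound 2 as follows: the two compounds have the same atoms and bonds; at least one stereo element is drawn with a configuration in one of them and without one in the other: 1 of 2 stereo elements differ; a stereocentre at a saturated ring carbon is drawn without a configuration in compound 2 and R in compound 3. Within the data shown here, no measured step bears on this kind of change: the step from compound 1 to compound 2 exchanges one aryl group for another, and says nothing about the stereocentre at a saturated ring carbon. For compound 3 the expected step of a 1.3-fold lower number from compound 2 to compound 3 (0.12 log units; within the scatter) therefore lies within the scatter, with a lean towards a lower number. On that basis compound 3 is estimated at 0.6 umol/kg, in a range from 0.25 umol/kg to 2 umol/kg, in this assay.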

Compound 3, dose for 50% inhibition: 66.9 umol/kg
Compound 3: middle estimate off by 110-fold (2.05 log units), on the low side; the whole stated range lies below it.
By their numbers in this assay, from the lowest: compound 2; then compound 1; then compound 3.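

In this assay, the stereocentre at a saturated ring carbon proves able to shift the read-out strongly with atoms and bonds unchanged, giving an 84-fold higher number from compound 2 to compound 3 (1.92 log units; beyond the scatter). Within the data shown here, the earlier step, an 18-fold lower number from compound 1 to compound 2 (1.26 log units; beyond the scatter), exchanged one aryl group for another and so showed only that the aryl group matters, whereas this one shows that the drawn configuration at this single centre also matters. The only difference between the two structures is a matter of stereochemistry: the fact that one of compounds 2 and 3 is drawn with a defined configuration and the other without, at the place where they differ

The compounds shown leave open how the S form of this centre would read, and what share of each configuration is present in compound 2, which is drawn without one. They also leave open how an ethyl group in place of the methyl on that ring carbon would read in either configuration.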